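The source may report more compounds than this note shows. Statements on the series, on what has been measured and on what is new or still open speak of the compounds shown alone.

Compound 1, `N#CC1=C(N)Oc2c(c3nc4ccccc4nc3c3ccccc23)C12C(=O)N(Cc1cnnn1-c1ccc(Cl)cc1)c1ccccc12`, in a functional assay on HCT-116 cells (Homo sapiens) for antiproliferative activity, read by MTT assay, with a stated time of 48 h (on this read-out lower numbers stand for stronger inhibition and higher numbers for weaker inhibition), gives > 50000 nM, which is a limit of the assay and not a number. Compound 2, `Cc1ccc(-n2nncc2CN2C(=O)C3(C(C#N)=C(N)Oc4c3c3nc5ccccc5nc3c3ccccc43)c3ccccc32)cc1C`, in this assay gives > 50000 nM, again a limit. Compound 3, `Cc1ccc(Cl)cc1-n1nncc1CN1C(=O)C2(C(C#N)=C(N)Oc3c2c2nc4ccccc4nc2c2ccccc32)c2ccccc21`, in this assay gives > 50000 nM, also a limit.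

Compound 3 therefore stands where the other two stand: at the edge of what this assay reports, with no number of its own. All three measured values sit at the limit of > 50000 nM in this assay, at which 3 of the 3 values shown sit. The three steps among them, a step that the two limits leave unreadable from compound 1 to compound 2, a step that the two limits leave unreadable from compound 1 to compound 3 and a step that the two limits leave unreadable from compound 2 to compound 3, cannot be read in size or direction, since each joins two limits.

Compound 4, `N#CC1=C(N)Oc2c(c3nc4ccccc4nc3c3ccccc23)C12C(=O)N(Cc1cnnn1-c1ccc(Cl)c(Cl)c1)c1ccccc12`, differs from compound 3 by 3,4-dichlorophenyl in place of 5-chloro-2-methylphenyl on an aromatic nitrogen. The change is of the same kind as those three unreadable steps: one substituted phenyl on the aromatic nitrogen exchanged for another, with the rest of the shared core unchanged. Nothing measured shows any such exchange moving the read-out off the limit, so no step beyond the scatter is expected in either direction.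

Compound 4 is therefore expected to remain at or near the limit, at 60000 nM with a range from 20000 nM to 200000 nM, which would mean an expected step that the limit leaves unreadable from compound 3 to compound 4.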

Compound 4, half-maximal inhibitory concentration: > 50000 nM
Compound 4: a limit, no number; the forecaster's own chance of this, stated with the estimate: 85%; the middle value is on the limit's open side.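

In this assay compound 4 gives > 50000 nM, which is a limit and not a number. Its steps from compound 1, compound 2 and compound 3 join limits and cannot be read in size or direction. The compounds shown leave open how far each lies past the limit and whether exchanging the substituted phenyl on the aromatic nitrogen changes the read-out at all.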